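The compounds below may be only part of what the source reports. "The series", "measured", "known", "first", "only" and "open" are said of these compounds alone.

In an ADME assay on MDCK cells (Canis lupus familiaris) for cytotoxicity (on this read-out higher numbers stand for lower toxicity in this test and lower numbers for higher toxicity in this test), compound 3 `CN(C(=O)C1(c2ccccc2)CCCC1)c1ccc(Cl)cc1` gives 20000 nM, the lower of the two plain numbers shown. Compound 1 `CN(C(=O)C1(c2ccccc2)CCCC1)c1ccccc1Cl` gives 23000 nM in this assay, and the step of a 1.2-fold lower number from compound 1 to compound 3 (0.06 log units; within the scatter) stays within the scatter. For compound 2 `CN(C(=O)C1(c2ccccc2)CCCC1)c1cccnc1` the result in this assay is only a limit, > 100000 nM (the limit of > 100000 nM in this assay, at which 1 of the 3 values shown sits). From it the steps of an at least 5.0-fold lower number from compound 2 to compound 3 (0.69 log units; beyond the scatter) and an at least 4.3-fold higher number from compound 1 to compound 2 (0.63 log units; beyond the scatter) are both beyond the scatter.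

Compound 4 `CN(C(=O)C1(c2ccccc2)CCCC1)c1ccc(C(F)(F)F)cc1` differs from compound 3 by trifluoromethyl in place of chloro on an aromatic carbon. Within the data shown here, no measured step swaps these two groups; the one step that keeps a carbon-only ring, a 1.2-fold lower number from compound 1 to compound 3 (0.06 log units; within the scatter), was small. The expected step is therefore no change at the digits printed from compound 3 to compound 4 (within the scatter), none beyond the scatter. Compound 4 is estimated at 20000 nM, between 7000 nM and 55000 nM.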

Compound 4, half-maximal cytotoxic concentration: 21000 nM
Compound 4: middle estimate off by 1.1-fold (0.02 log units), on the low side, and the stated range covers the measured number.
By their numbers in this assay, from the lowest: compounds 3, 4 and 1 (each within the scatter of the next). At a limit, above all of these: compound 2.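

The change gives a 1.1-fold higher number from compound 3 to compound 4 (0.02 log units; within the scatter) in this assay and so no real difference: on this aromatic carbon, para to a large group, trifluoromethyl with its four heavy atoms reads the same as chloro with its one. Among these compounds, until now, only chloro had been seen on this carbon-only ring, so this is the first sign that a different group can sit here without moving the number. Nothing measured here explains why the two groups match.

Going by these compounds, whether an amine or a carboxylic acid at this position would also leave the number in place remains open.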